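The compounds below may be only part of what the source reports. "The series", "measured", "known", "first", "only" and "open" are said of these compounds alone.

Working notes on the series. Three compounds have numbers in a functional assay on HCT-116 cells (Homo sapiens) for antiproliferative activity, read by MTT assay, with a stated time of 72 h; on this read-out higher numbers stand for weaker inhibition and lower numbers for stronger inhibition. For the measured compounds named here, compound 1 `NC1=NC2(CCSCC2)N(OCCCOc2cccc(Cl)c2Cl)C(N)=N1` gives 1 nM, and compound 3 `NC1=NC2(CCSCC2)N(OCCCOc2ccc(Cl)cc2)C(N)=N1` gives 10 nM; the one step between them, a 10-fold higher number from compound 1 to compound 3 (1.00 log units; beyond the scatter), is the only single-change step on record. Compound 2 `Cc1ccc(OCCCON2C(N)=NC(N)=NC23CCOCC3)cc1` gives 2390 nM, the highest of the three numbers, far above compound 3 and further still above compound 1; it differs from both in more than one place, so those gaps are read only as what the two values show.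

Compound 4 `NC1=NC2(CCOCC2)N(OCCCOc2cccc(Br)c2)C(N)=N1` is unmeasured. The change from compound 2 is 3-bromophenyl in place of 4-methylphenyl on an oxygen on a saturated carbon. Going by the values given here, no measured step covers a methyl-to-halogen swap on this ring, or any change on the core of compound 2. What bears on it is that both halogenated compounds sit far below compound 2, while the step of a 10-fold higher number from compound 1 to compound 3 (1.00 log units; beyond the scatter) shows that the pattern of halogens on the ring moves the number by a modest amount. A move toward the halogenated compounds is therefore expected for compound 4, with wide uncertainty given the different core. The expected step is a 12-fold lower number from compound 2 to compound 4 (1.08 log units; beyond the scatter). The estimate for compound 4 in this assay is 200 nM, with a range from 25 nM to 1600 nM.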

Compound 4, half-maximal inhibitory concentration: 40 nM
Beside the measured number, compound 4's estimate is 5.0-fold (0.70 log units) above it, and the stated range covers the measured number.
By their numbers in this assay, from the lowest: compound 1; then compound 3; then compound 4; then compound 2.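

In this assay the group on the oxygen of the three-carbon chain now has a single-change step on the core of compound 2: 3-bromophenyl in place of 4-methylphenyl gives a 60-fold lower number from compound 2 to compound 4 (1.78 log units; beyond the scatter), a large step. For the compounds shown here, the only earlier single-change step at this place was a 10-fold higher number from compound 1 to compound 3 (1.00 log units; beyond the scatter), a modest one between two chlorinated rings on the core of compound 1, so this is the first sign that a change on the ring alone, with the core of compound 2 held fixed, can move the number by a large amount. Nothing on hand accounts for the size of this step.

The compounds shown leave open whether the step follows from bromine replacing methyl or from the different ring place of the substituent, a question that 4-bromophenyl or 3-methylphenyl on the core of compound 2 would settle. Also open are how much the core itself contributes, since no aryl group shown appears on both cores, and whether a ring carrying an amine or a carboxylic acid would keep the lower number.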